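The source may hold more compounds than are shown below. What is called first, only, known or untested is meant among the compounds shown, and "the series" means these compounds.

Values in a functional assay on HeLa cells (Homo sapiens) for cytotoxicity, read by ELISA, with a stated time of 2 days (a lower number here means a stronger inhibitor, a higher number a weaker inhibitor), so far
- compound 1 `Oc1ccccc1-c1cc(-c2ccccc2)nc(-c2ccco2)c1` gives 9700 nM
- compound 2 `Oc1cccc(-c2cc(-c3ccccc3)nc(-c3ccncc3)c2)c1` gives 15000 nM
- compound 3 `Oc1ccc(-c2cc(-c3ccccc3)nc(-c3ccco3)c2)cc1` gives 4500 nM

Compound 3 has the lowest of these three numbers, with compound 1 nearest and compound 2 furthest. Going on to compound 4 `Oc1ccc(-c2cc(-c3ccccc3)nc(-c3ccncc3)c2)cc1` means the change pyridin-4-yl in place of furan-2-yl on an aromatic carbon in which pyridin-4-yl takes the place of furan-2-yl on the aromatic carbon next to the ring nitrogen.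

Among the measured compounds shown here, the one measured step, a 2.2-fold lower number from compound 1 to compound 3 (0.33 log units; beyond the scatter) is modest, but it moves the hydroxyl and keeps furan-2-yl, so it bears on this change only as a guide to size. Compound 2 also carries pyridin-4-yl and gives 15000 nM but its hydroxyl sits elsewhere, so the two differences from compound 3 cannot be separated. A modest rise in the number in this assay is therefore expected, with no change beyond the scatter still possible.

The estimated step is a 2.1-fold higher number from compound 3 to compound 4 (0.32 log units; beyond the scatter) and would be a modest one. For compound 4 the estimate is 9500 nM with an expected range from 4000 nM to 20000 nM as its ends.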

Compound 4, half-maximal inhibitory concentration: 1600 nM
Compound 4: middle estimate off by 5.9-fold (0.77 log units), on the high side; the measured number lies below the stated range.
By their numbers in this assay, from the lowest: compound 4; then compound 3; then compounds 1 and 2 (each within the scatter of the next).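

In this assay, with 4-hydroxyphenyl held fixed, pyridin-4-yl in place of furan-2-yl on the aromatic carbon next to the ring nitrogen gives a 2.8-fold lower number from compound 3 to compound 4 (0.45 log units; beyond the scatter), so this position responds to the exchange and the number falls rather than rises. With pyridin-4-yl held fixed, 4-hydroxyphenyl in place of 3-hydroxyphenyl gives a 9.4-fold lower number from compound 2 to compound 4 (0.97 log units; beyond the scatter), which separates the hydroxyl position from the exchange of rings that compound 2 and compound 3 left tangled. Nothing available explains either step.

The compounds shown leave open whether the ring nitrogen itself matters at this carbon, which pyridin-3-yl or a plain phenyl there would test. Also open, going by these compounds, is how an amine or a carboxylic acid on this ring would read in this assay.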